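Moving a phenyl along a short side chain

The source may report more compounds than this note shows. Statements on the series, on what has been measured and on what is new or still open speak of the compounds shown alone.

Compound 1 `CC(c1ccccc1)c1nc2c(C(F)(F)F)cccc2c(C(=O)O)c1O` gives 1550 ug/mL
Compound 2 `CC(C)(c1ccccc1)c1nc2c(C(F)(F)F)cccc2c(C(=O)O)c1O` gives 2810 ug/mL
Compound 3 `CC(Cc1ccccc1)c1nc2c(C(F)(F)F)cccc2c(C(=O)O)c1O` gives 1550 ug/mL
Compound 4 `CC(Cc1nc2c(C(F)(F)F)cccc2c(C(=O)O)c1O)c1ccccc1` is still unmeasured

These compounds share one core and differ only in the side chain attached to it. In a physicochemical assay for solubility, at pH 6.6 (on this read-out higher numbers stand for higher solubility and lower numbers for lower solubility), compound 3 gives 1550 ug/mL and stands level with compound 1, while compound 2 lies within the scatter of both.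

Compound 4 has the same atoms as compound 3, joined differently. It carries 2-phenylpropyl in place of 1-benzylethyl on an aromatic carbon next to the ring nitrogen (2-phenylpropyl in place of 1-benzylethyl on an aromatic carbon).

Among the compounds with values here, three measured steps bear on this, all of them changes to the same side chain: (no change at the digits printed from compound 1 to compound 3 (within the scatter)), (a 1.8-fold higher number from compound 1 to compound 2 (0.26 log units; within the scatter)) and (a 1.8-fold lower number from compound 2 to compound 3 (0.26 log units; within the scatter)). Each is within the scatter, the range over which repeat measurements of a single compound can differ. Within the data shown here, none of them tests this exact rearrangement, so they point in no direction for this assay and suggest only that such changes have been small here.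

The expected step is therefore none beyond the scatter, estimated as (a 1.2-fold higher number from compound 3 to compound 4 (0.06 log units; within the scatter)). Compound 4 is estimated at 1800 ug/mL with a range from 850 ug/mL to 3600 ug/mL as the expected span.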

Compound 4, solubility: 680 ug/mL
Compound 4: middle estimate off by 2.6-fold (0.42 log units), on the high side, and the stated range ends above it.
By their numbers in this assay, from the lowest: compound 4; then compounds 1, 3 and 2 (each within the scatter of the next).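

In this assay, the exact way the side chain is joined at this aromatic carbon, next to the ring nitrogen, turns out to matter: putting 2-phenylpropyl in place of 1-benzylethyl, with no atom gained or lost, gives (a 2.3-fold lower number from compound 3 to compound 4 (0.36 log units; beyond the scatter)), the first step among these compounds to lie beyond the scatter. The same holds against the other two side chains, with (a 2.3-fold lower number from compound 1 to compound 4 (0.36 log units; beyond the scatter)) and (a 4.1-fold lower number from compound 2 to compound 4 (0.62 log units; beyond the scatter)), so compound 4 is the lowest of the four, although all three steps are modest and its solubility is still far from abolished in absolute terms. Compound 4 also differs from the other three in one visible way, since its side chain alone has an unbranched first carbon on the core, but no measurement here explains the drop.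

The compounds shown leave open whether the lower number goes with that unbranched first carbon or with the methyl further along the chain, a question that a straight 3-phenylpropyl or 2-phenylethyl chain would help to answer. They also say nothing about how a side chain carrying an amine would behave at this position.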